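The compounds below may be only part of what the source reports. "The series", "measured", "known", "first", "only" and "open" are said of these compounds alone.

Series notes. Three measured compounds share one core and differ only in the aryl group on a saturated chain carbon bound to an amine nitrogen. In a functional assay on CCRF-CEM cells for antagonist activity at C-X-C chemokine receptor type 4 (Homo sapiens), read by calcium flux, with stated times of 25 min and 90 s (on this read-out higher numbers stand for weaker inhibition and lower numbers for stronger inhibition), compound 1 `c1ccc2c(c1)CN[C@H](CN(CCCN1CCNCC1)[C@H]1CCCc3cccnc31)C2` gives 1150 nM. In this assay compound 2 `c1cnc2c(c1)CCC[C@@H]2N(CCCN1CCNCC1)Cc1nc2ccccc2[nH]1` gives 45 nM. In this assay compound 3 `c1cnc2c(c1)CCC[C@@H]2N(CCCN1CCNCC1)Cc1nc2ccccc2s1` gives 1200 nM. Compound 3 thus carries the highest number of the three, though it sits within the scatter of compound 1 (a 1.0-fold higher number from compound 1 to compound 3 (0.02 log units; within the scatter)) and far from compound 2 (a 27-fold higher number from compound 2 to compound 3 (1.43 log units; beyond the scatter)). The only large move in the set is a 26-fold lower number from compound 1 to compound 2 (1.41 log units; beyond the scatter).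

Compound 4 `c1cnc(CN(CCCN2CCNCC2)[C@H]2CCCc3cccnc32)nc1` is not yet measured. The change is pyrimidin-2-yl in place of 1,3-benzothiazol-2-yl on a saturated chain carbon bound to an amine nitrogen. For the measured compounds named here, the steps that bear on it are the aryl swaps at the same place: a 27-fold higher number from compound 2 to compound 3 (1.43 log units; beyond the scatter) shows that the 1H-benzimidazol-2-yl group is what separates the set, and the pyrimidin-2-yl group, like the 1,3-benzothiazol-2-yl group, brings 0 hydrogen-bond donors. Going by the values given here, no measured step goes from compound 3 to a smaller ring, so direction is uncertain; a move within the scatter or toward a higher number seems more likely than a return toward compound 2. The expected step is a 1.7-fold higher number from compound 3 to compound 4 (0.22 log units; within the scatter). Compound 4 is therefore estimated at 2000 nM, with a range from 500 nM to 8000 nM.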

Compound 4, half-maximal inhibitory concentration: 4320 nM
The estimate for compound 4 lay 2.2-fold (0.33 log units) below the measured number, within the range that was stated.
By their numbers in this assay, from the lowest: compound 2; then compounds 1 and 3 (each within the scatter of the next); then compound 4.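

The change to pyrimidin-2-yl gives a 3.6-fold higher number from compound 3 to compound 4 (0.56 log units; beyond the scatter) in this assay and so shows that two groups with 0 hydrogen-bond donors need not read alike at this position, on a saturated chain carbon bound to an amine nitrogen. For the compounds shown here, the same change gives a 3.8-fold higher number from compound 1 to compound 4 (0.57 log units; beyond the scatter) and a 96-fold higher number from compound 2 to compound 4 (1.98 log units; beyond the scatter) as well, so the single six-membered aromatic ring with 2 hetero atoms stands apart from compound 1 and compound 3, which lie within the scatter of each other, and the span of numbers at this position is wider than the earlier compounds showed. Nothing available explains why this change moves the number as it does.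

The compounds shown do not separate the loss of the five-membered aromatic ring from the change in ring hetero atoms, a question that a pyridin-2-yl or a 1,3-benzoxazol-2-yl group at the same place would bear on. As far as these compounds go, whether the ring nitrogen hydrogen of the 1H-benzimidazol-2-yl group can carry compound 2's number without the fused ring also stays open, and a 1H-imidazol-2-yl group would address it.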